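Swapping trifluoromethyl for fluoro on a weak cytotoxic pair

The compounds below may be only part of what the source reports. "The series", "measured", "known", "first", "only" and "open" are said of these compounds alone.

Measured compounds:
- compound 1 `COc1cc2ncnc(NNC(=S)NC(=O)c3ccc(C(F)(F)F)cc3)c2cc1OC`: 16500 nM
- compound 2 `O=C(NC(=S)NNc1ncnc2ccccc12)c1ccc(C(F)(F)F)cc1`: 12200 nM

Among the measured compounds shown here, only two compounds have numbers so far, and both were tested in a functional assay on GLC82 cells (Homo sapiens) for cytotoxicity, read by MTT assay, with a stated time of 72 h; on this read-out higher numbers stand for weaker inhibition and lower numbers for stronger inhibition. Compound 1 gives 16500 nM, which is the higher of the two numbers. Compound 2 gives 12200 nM. The gap between them lies within the scatter of this kind of measurement, so neither can be called the stronger inhibitor; both sit at weak potency on this read-out.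

Compound 3 `COc1cc2ncnc(NNC(=S)NC(=O)c3ccc(F)cc3)c2cc1OC` is the next compound and has not yet been measured. It differs from compound 1 in one place: fluoro in place of trifluoromethyl on an aromatic carbon. The shared core and the acyl thiosemicarbazide linker are kept unchanged.

For the measured compounds named here, no measured pair in this set shows what this change does, so there is no step to lean on. With nothing pointing either way, the step from compound 1 to compound 3 in this assay is expected to be small, a 1.2-fold higher number from compound 1 to compound 3 (0.08 log units; within the scatter), most likely none beyond the scatter. Compound 3 is therefore estimated to give about 20000 nM, within a range of 8000 nM to 50000 nM.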

Compound 3, half-maximal inhibitory concentration: 15300 nM
Compound 3: middle estimate off by 1.3-fold (0.12 log units), on the high side; low and high end bracket the measured number.
By their numbers in this assay, from the lowest: compounds 2, 3 and 1 (each within the scatter of the next).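

In this assay, fluoro in place of trifluoromethyl on this aromatic carbon gives a 1.1-fold lower number from compound 1 to compound 3 (0.03 log units; within the scatter), so this first direct comparison at the position cannot tell the two compounds apart. Going from a group of 4 heavy atoms to one of 1 heavy atom, with the rest of the molecule kept the same, therefore has no effect that can be seen beyond the scatter, and both compounds remain weak on this read-out. No measured evidence here explains why the two groups read alike, so this stands as an observation about these two compounds only.

What the compounds shown leave open is whether any group at this position can move the number beyond the scatter, for example an amine, a carboxylic acid or a longer carbon chain, since two groups that read alike say little about the range the position allows. As far as these compounds go, it also remains open whether the same swap from 4-(trifluoromethyl)phenyl to 4-fluorophenyl would read the same way on the core of compound 2.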